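Phenyl for acetyl on the piperazine ring

A few compounds are considered here, and "the series" means these few. Any claim that something is new, unique, unknown or untested is made for them only; others in the source may bear on it.

Measured compounds:
compound 1 `CC(=O)N1CCN(c2nc(Nc3ccc(C#N)c(C(F)(F)F)c3)nc(Oc3ccnc4ccccc34)n2)CC1` gives > 100000 nM in a functional assay on DU-145 cells (Homo sapiens) for cytotoxicity, read by sulforhodamine B assay, with a stated time of 48 h (on this read-out higher numbers stand for weaker inhibition of growth and lower numbers for stronger inhibition of growth), a limit of the assay.
compound 2 `N#Cc1ccc(Nc2nc(Oc3ccnc4ccccc34)nc(N3CCN(C(c4ccccc4)c4ccccc4)CC3)n2)cc1C(F)(F)F` gives > 100000 nM in this assay, also a limit.

Compound 1 sits at the limit of the assay, as does compound 2; neither value is a number, so no order between them can be read. Both values sit at the limit of > 100000 nM in this assay, at which 2 of the 2 values shown sit. Compound 3 `N#Cc1ccc(Nc2nc(Oc3ccnc4ccccc34)nc(N3CCN(c4ccccc4)CC3)n2)cc1C(F)(F)F` is not yet measured. It differs from compound 1 by phenyl in place of acetyl on an amine nitrogen in a ring. Among the measured compounds shown here, no step between measured compounds is available here, so the size of the change cannot be anchored on a measured pair. With both measured values at a limit, the step that the limit leaves unreadable from compound 1 to compound 3 is expected to be small and most likely the result will again be a limit rather than a number. Compound 3 is estimated at 120000 nM, with a range from 20000 nM to 500000 nM.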

Compound 3, concentration for total growth inhibition: > 100000 nM
Compound 3 was reported as a limit; the forecaster's own chance of this, stated with the estimate: 75%; the middle value is on the limit's open side.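

In this assay compound 3 gives > 100000 nM as a limit of the assay, so no step can be read for phenyl in place of acetyl going from compound 1 to compound 3. Whether any group at this place alters growth inhibition stays open, because no value shown is a number: the limit of > 100000 nM in this assay, at which 3 of the 3 values shown sit.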